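Swapping Amino for Methyl on a Hydroxamic Acid Core

A few compounds are considered here, and "the series" means these few. Any claim that something is new, unique, unknown or untested is made for them only; others in the source may bear on it.

Two hydroxamic acids have been measured in an assay on Sf9 cells for inhibition of protein deacetylase HDAC6 (Homo sapiens), read by fluorescence; a lower number here means a stronger inhibitor, a higher number a weaker inhibitor. Compound 1 `Cc1ccc(C(=O)NO)cc1F` carries a methyl group and a single fluoro group on its aromatic ring; in this assay compound 1 gives 49 nM. Compound 2 `Nc1c(F)cc(C(=O)NO)cc1F` instead carries an amino group flanked by two fluoro groups; in this assay compound 2 gives 112 nM. Of the two numbers, compound 2 has the higher one, and its gap to compound 1 lies beyond the usual scatter of this measurement.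

Compound 3 `Cc1c(F)cc(C(=O)NO)cc1F` has not yet been measured. It differs from compound 2 in one place: methyl in place of amino on an aromatic carbon. Since compound 1, which carries the methyl group, gives 49 nM, the step is expected to move the number downward, toward stronger inhibition, by a modest margin that may or may not exceed the scatter. The expected step is a 1.9-fold lower number from compound 2 to compound 3 (0.27 log units; within the scatter). Compound 3 is therefore estimated at 60 nM in this assay, with a likely range from 25 nM to 150 nM.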

Compound 3, half-maximal inhibitory concentration: 27 nM
Beside the measured number, compound 3's estimate is 2.2-fold (0.35 log units) above it; the range from low to high includes it.
By their numbers in this assay, from the lowest: compounds 3 and 1 (each within the scatter of the next); then compound 2.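

With both fluoro groups held constant, the change of methyl in place of amino on this aromatic carbon, ortho to two fluoro groups and para to a hydroxycarbamoyl group, gives a 4.1-fold lower number from compound 2 to compound 3 (0.62 log units; beyond the scatter) in this assay. Going by these compounds alone, compounds 1 and 2 differ in more than one place, so only this new pair isolates the swap and shows that the group at this position alone can move the number beyond the scatter. The other new step, fluoro in place of hydrogen on an aromatic carbon, gives a 1.8-fold lower number from compound 1 to compound 3 (0.26 log units; within the scatter), so with methyl present the added fluoro group produces no change that can be told from the scatter. Nothing available gives a reason for either step.

Going by these compounds, it remains open whether the amino-to-methyl step would keep its size on a ring with a single fluoro group, since this pair shows it only with two. On these data alone, it is also open where a hydroxyl group, a methoxy group or an ethyl chain on the same aromatic carbon would fall relative to compound 2 and compound 3.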